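Capping a hydroxy group as methoxy

This account rests on a few compounds, and the source may have more. Where it says the series, first, only, none or still open, it means among the compounds named here.

Going by the values given here, only two compounds have numbers so far, which leaves little to build on. Compound 1 (`Nc1ccc(/C=C/c2cccc(O)c2)cc1`) gives 42 ug/mL in a functional assay on HT-29 cells (Homo sapiens) for inhibition, read by MTT assay, with a stated time of 2 days (a higher number here means a weaker inhibitor, a lower number a stronger inhibitor), and provides the first reference point. Compound 2 (`Nc1ccc(/C=C/c2ccc(O)cc2)cc1`) gives 30.6 ug/mL in this assay as well. These two numbers lie within the usual scatter of repeated measurements, so compound 2 stands level with compound 1 and neither can be ranked ahead of the other.

Compound 3 (`COc1ccc(/C=C/c2ccc(N)cc2)cc1`) is built from compound 2 by one small edit: methyl in place of hydrogen on an oxygen on an aromatic ring. In plain terms, hydroxy becomes methoxy. Among the compounds with values here, no measured pair shows what this edit does in this assay, so the data offer no direction to lean on. The natural starting point is to expect compound 3 to stay close to compound 2, with a wide margin for the unknown. The estimate is therefore a 1.0-fold lower number from compound 2 to compound 3 (0.01 log units; within the scatter) with no direction favoured, which means no expected step beyond the scatter. The estimate for compound 3 is 30 ug/mL with an expected range of 13 ug/mL to 70 ug/mL when it is measured.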

Compound 3, half-maximal inhibitory concentration: 0.0036 ug/mL
The estimate for compound 3 lay 8300-fold (3.92 log units) above the measured number, and the stated range ends above it.
By their numbers in this assay, from the lowest: compound 3; then compounds 2 and 1 (each within the scatter of the next).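

Compounds 1 and 2, which both carry a free hydroxy group, stand level in this assay, and that pair gave no sign that this oxygen had much bearing on the result. Compound 3 shows that what sits on this oxygen on an aromatic ring can matter enormously: swapping the hydrogen for a methyl, which adds only one carbon as a heavy atom, gives an 8500-fold lower number from compound 2 to compound 3 (3.93 log units; beyond the scatter), a large step far beyond the scatter. No supporting measurement is available to account for a step of this size from so small an edit.

As far as these compounds go, this is a single pair, so it remains open whether the same capping would give a similar step on the hydroxy group of compound 1, whose oxygen sits at a different place on the ring. From the compounds shown here alone, it is also open whether the gain depends on methyl itself or would hold with a longer chain on the same oxygen, such as ethyl, or with a different group in place of the methoxy, such as a fluorine atom or an amine.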